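Methoxy removal on the aryl group of a fatty acid receptor agonist

The compounds below may be only part of what the source reports. "The series", "measured", "known", "first", "only" and "open" are said of these compounds alone.

Measured compounds:
compound 1 `CC#CC(CC(=O)O)c1ccc(OCc2ccc3nc(-c4ccc(OC)cc4)cn3c2)cc1`: 47 nM
compound 2 `CC#CC(CC(=O)O)c1ccc(OCc2ccn3cc(-c4cc(F)ccc4F)nc3c2)cc1`: 639 nM

In an assay on isolated protein for agonist activity at Free fatty acid receptor 1 (Homo sapiens) (on this read-out higher numbers stand for an effect only at larger amounts of compound and lower numbers for an effect already at smaller amounts), compound 1 gives 47 nM, the lowest of the two numbers. Compound 2 gives 639 nM, a gap to compound 1 that lies beyond the usual scatter. Compound 3 `CC#CC(CC(=O)O)c1ccc(OCc2ccc3nc(-c4ccccc4)cn3c2)cc1` awaits measurement in this assay. It differs from compound 1 by hydrogen in place of methoxy on an aromatic carbon. Among the measured compounds shown here, no measured pair shows this change on the shared core, so the expected step of a 1.8-fold higher number from compound 1 to compound 3 (0.26 log units; within the scatter) is modest, if anything toward a higher number, and may stay within the scatter. Compound 3 is estimated at 85 nM, with a range from 30 nM to 250 nM.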

Compound 3, half-maximal effective concentration: 979 nM
Compound 3: the middle estimate sits 12-fold (1.06 log units) below what was measured, and the stated range ends below it.
By their numbers in this assay, from the lowest: compound 1; then compounds 2 and 3 (each within the scatter of the next).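

Among the compounds shown here, the change from 4-methoxyphenyl to phenyl in this assay gives a 21-fold higher number from compound 1 to compound 3 (1.32 log units; beyond the scatter) and is the first single-place comparison. The low number of compound 1 therefore depends on the methoxy group on this aromatic carbon, para to a large group. A change of only 2 heavy atoms at this place moves the read-out well beyond the scatter. Still open, as far as these compounds go, is whether methoxy itself is required, or whether an ethoxy, a hydroxyl or a dimethylamino group at the same carbon would hold the low number. No data at hand give a reason for the step.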